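The compounds below may be only part of what the source reports. "The series", "measured", "known", "first", "only" and "open" are said of these compounds alone.

Measured so far in an assay on cells for agonist activity at probable G-protein coupled receptor 34 (Mus musculus), with a stated time of 1 h; on this read-out lower numbers stand for smaller maximal responses and higher numbers for larger maximal responses:
- compound 1, `N[C@@H](COP(=O)(O)OCCCOC(=O)CCc1ccccc1OCc1cccc(OC2CCCCC2)c1)C(=O)O`: 18.8%
- compound 2, `N[C@@H](COP(=O)(O)OCCCOC(=O)CCc1ccccc1OCc1cccc(Oc2ccc(Br)cc2)c1)C(=O)O`: 17.7%

Compound 2 stands lowest of the two numbers in this assay, with compound 1 the nearest, a number within the scatter. The only step shown, a number 1.1 percentage points lower from compound 1 to compound 2 (within the scatter), replaced cyclohexyl with 4-bromophenyl on an oxygen on an aromatic ring and left the read-out unchanged beyond the scatter.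

Compound 3, `CCc1ccc(Oc2cccc(COc3ccccc3CCC(=O)OCCCOP(=O)(O)OC[C@H](N)C(=O)O)c2)cc1`, differs from compound 2 by ethyl in place of bromo on an aromatic carbon. No measured step bears directly on this exchange; the one step shown, a number 1.1 percentage points lower from compound 1 to compound 2 (within the scatter), touched the same oxygen-linked position but swapped a whole ring rather than a substituent on it. Given that both measured compounds sit close together, compound 3 is expected to stay in the same band, with a number 0.3 percentage points higher from compound 2 to compound 3 (within the scatter) and no movement beyond the scatter. The estimate for compound 3 in this assay is 18%, with a range from 8% to 30%.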

Compound 3, largest response reached (Emax), in percent of the reference or control that the assay uses: 19.3%
For compound 3 the middle estimate is 1.3 percentage points below the measured one; the measured number falls inside the stated range.
By their numbers in this assay, from the lowest: compounds 2, 1 and 3 (each within the scatter of the next).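

On the aromatic carbon para to a large group, ethyl in place of bromo gives a number 1.6 percentage points higher from compound 2 to compound 3 (within the scatter) in this assay, so an alkyl group and a halogen at this position read the same within the scatter. Set against the saturated ring, the 4-ethylphenyl group gives a number 0.5 percentage points higher from compound 1 to compound 3 (within the scatter), which places cyclohexyl, 4-bromophenyl and 4-ethylphenyl on this oxygen in a single band of maximal response. Nothing at hand gives a reason for this flat read-out.

From the compounds shown here alone, whether a group of another kind at this position, such as an amine, a carboxylic acid or a longer alkyl chain, would move the response beyond the scatter stays open. Going by these compounds, the shared core is constant across all three compounds, so what its parts contribute to the response also remains open.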